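The source may hold more compounds than are shown below. What is called first, only, known or untested is meant among the compounds shown, and "the series" means these compounds.

In a functional assay on MCF7 cells (Homo sapiens) for antiproliferative activity, read by MTT assay (on this read-out higher numbers stand for weaker inhibition and lower numbers for stronger inhibition), the measured compounds are:
compound 1 `COc1cc2c(Oc3ccc(NC(=O)Nc4cccc(C)c4)cc3)ccnc2cc1OCCCCCCC(=O)NO` at 1240 nM
compound 2 `COc1cc2c(Oc3ccc(NC(=O)N/N=C/c4ccccc4F)cc3)ccnc2cc1OCCCCCCC(=O)NO` at 1610 nM
compound 3 `COc1cc2c(Oc3ccc(NC(=O)NNC(=O)c4ccccc4)cc3)ccnc2cc1OCCCCCCC(=O)NO` at 2450 nM

Compound 3 lies within the scatter of both other compounds (a 2.0-fold higher number from compound 1 to compound 3 (0.30 log units; within the scatter) and a 1.5-fold higher number from compound 2 to compound 3 (0.18 log units; within the scatter)). Compound 4 (`COc1cc2c(Oc3ccc(NC(=O)NNC(=O)c4cccc(C)c4)cc3)ccnc2cc1OCCCCCCC(=O)NO`) differs from compound 3 by one change (methyl in place of hydrogen on an aromatic carbon), methyl in place of hydrogen on an aromatic carbon, meta to a large group. Among the compounds with values here, no measured step isolates this change. The closest evidence is whole-group replacement on an amide-type nitrogen (a 1.3-fold higher number from compound 1 to compound 2 (0.11 log units; within the scatter) and a 2.0-fold higher number from compound 1 to compound 3 (0.30 log units; within the scatter)), and both steps stay within the scatter. No step beyond the scatter is therefore expected in this assay for this methyl, and the estimate means only a small expected step (a 1.2-fold lower number from compound 3 to compound 4 (0.07 log units; within the scatter)). For compound 4 the estimated value is 2100 nM with an expected range (1050 nM to 4200 nM).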

Compound 4, half-maximal inhibitory concentration: 5830 nM
For compound 4 the middle estimate is 2.8-fold (0.44 log units) below the measured one, outside the stated range (above it).
By their numbers in this assay, from the lowest: compounds 1, 2 and 3 (each within the scatter of the next); then compound 4.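

In this assay, methyl in place of hydrogen on an aromatic carbon, meta to a large group, gives the first single-site change shown with a step beyond the scatter (a 2.4-fold higher number from compound 3 to compound 4 (0.38 log units; beyond the scatter)). Compound 4 also stands beyond the scatter of the other two compounds (a 3.6-fold higher number from compound 2 to compound 4 (0.56 log units; beyond the scatter); a 4.7-fold higher number from compound 1 to compound 4 (0.67 log units; beyond the scatter)), so this ring position responds to even one added carbon. No evidence on the origin of this step is available.

As far as these compounds go, whether a methoxy group or a chlorine atom at this place moves the number in the same direction remains open.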